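Methoxy removal and the cytotoxicity read-out in this series

The source may hold more compounds than are shown below. What is called first, only, known or untested is meant among the compounds shown, and "the series" means these compounds.

Three esters carry the same acyl part and differ only on the aromatic ring bearing the 2-carboxyethenyl group. In a functional assay on EA.hy 926 cells (Homo sapiens) for cytotoxicity, read by MTT assay, with stated times of 24 h and 12 h, tested at 50 uM (on this read-out lower numbers stand for a weaker effect and higher numbers for a stronger effect at the one concentration tested), compound 3 `COc1cc(/C=C/C(=O)O)cc(OC)c1OC(=O)c1nc(C)c(C)nc1C` gives 96.6%, compound 1 `COc1cc(/C=C/C(=O)O)ccc1OC(=O)c1nc(C)c(C)nc1C` gives 49.1%, and compound 2 `COc1ccc(/C=C/C(=O)O)cc1OC(=O)c1nc(C)c(C)nc1C` gives 160%, the highest of the three. From compound 3 to compound 1 the change is hydrogen in place of methoxy on an aromatic carbon; its effect is a number 47.5 percentage points lower from compound 3 to compound 1 (beyond the scatter). The same kind of change, (hydrogen in place of methoxy on an aromatic carbon), leads to compound 4 `Cc1nc(C)c(C(=O)Oc2cccc(/C=C/C(=O)O)c2)nc1C`, though here the place is para to the 2-carboxyethenyl group rather than meta to it and to a methoxy group. The difference between the cores of compound 2 and compound 3 is not broken down here. Going by the values given here, because the one measured instance gave a number 47.5 percentage points lower from compound 3 to compound 1 (beyond the scatter), the expected step is a number 60 percentage points lower from compound 2 to compound 4 (beyond the scatter), with wide uncertainty. Compound 4 is estimated at 100%, expected between 55% and 150%.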

Compound 4, a percentage reported as activity, at one concentration (the size of the read-out at that concentration, not a potency): 75.3%
Compound 4: middle estimate off by 24.7 percentage points, on the high side, within the range that was stated.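

In this assay the step is a number 84.7 percentage points lower from compound 2 to compound 4 (beyond the scatter) and so runs the same way as the earlier one, but two instances make no general rule for this series. The change also sits at a different place on each core, para to a 2-carboxyethenyl group in compound 4, so these compounds cannot separate the influence of place from that of core, and they give no cause for the gap. The direction carries from one core to the other, while the size does not: the same change on two cores in this assay, a number 47.5 percentage points lower (beyond the scatter) from compound 3 to compound 1 and a number 84.7 percentage points lower (beyond the scatter) from compound 2 to compound 4, 37.2 percentage points apart, beyond the scatter of two such steps.

As far as these compounds go, what a hydroxy group, a chlorine atom or an amine would give in place of methoxy stays open. So does the effect of a longer alkoxy chain at the same carbon.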